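Changing the Aryl Group on an Aromatic-Ring Nitrogen

A few compounds are considered here, and "the series" means these few. Any claim that something is new, unique, unknown or untested is made for them only; others in the source may bear on it.

Three compounds have been measured in a functional assay on PC-9 cells (Homo sapiens) for inhibition, read by MTT assay, with a stated time of 48 h, tested at 10 uM; on this read-out higher numbers stand for more inhibition at the one concentration tested (going by the name of the read-out) and lower numbers for less inhibition:
Compound 1 `COc1cc(NC(=O)Nc2cc(Nc3ccc(OC)c(C)c3)ncn2)cc(OC)c1` gives 62%
Compound 2 `COc1cc(NC(=O)Nc2cc(Nc3cc(Br)ccc3OC)ncn2)cc(OC)c1` gives 82.5%
Compound 3 `CCc1ccc(Nc2cc(NC(=O)Nc3c(Cl)cccc3Cl)ncn2)cc1` gives 70.1%

Compound 3 stands second highest of the three: compound 1 lies close to it, within the usual scatter, while compound 2 sits above it by more than the scatter. Compound 4 `COc1ccc(F)cc1Nc1cc(NC(=O)Nc2c(Cl)cccc2Cl)ncn1` differs from compound 3 by 5-fluoro-2-methoxyphenyl in place of 4-ethylphenyl on a nitrogen on an aromatic ring. For the measured compounds named here, one measured step bears on this: a number 20.5 percentage points higher from compound 1 to compound 2 (beyond the scatter), where the group on that same nitrogen was exchanged for 5-bromo-2-methoxyphenyl, which, like the entering 5-fluoro-2-methoxyphenyl, carries a methoxy and a halogen. Going by the values given here, a rise of similar kind is therefore expected, though the single precedent makes it uncertain, estimated as a number 9.9 percentage points higher from compound 3 to compound 4 (within the scatter). Compound 4 is expected to give about 80%, within a range from 63% to 93%.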

Compound 4, a percentage reported as inhibition, at one concentration (the size of the read-out at that concentration, not a potency): 85.5%
For compound 4 the middle estimate is 5.5 percentage points below the measured one; measured number inside the range.
By their numbers in this assay, from the lowest: compounds 1 and 3 (each within the scatter of the next); then compounds 2 and 4 (each within the scatter of the next).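

In this assay, 5-fluoro-2-methoxyphenyl on this nitrogen gives a number 15.4 percentage points higher from compound 3 to compound 4 (beyond the scatter). A phenyl group carrying a methoxy and a halogen has now gone with the higher number in two separate pairs, and the second pair has a different group at the other end of the molecule, so the gain is not confined to one partner. No measurement shown offers an explanation for this rise.

The compounds shown leave open whether the methoxy, the halogen or the two together account for the rise. From the compounds shown here alone, how an amine or a carboxylic acid on this phenyl ring would read also remains open.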